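The source may hold more compounds than are shown below. What is called first, only, known or untested is meant among the compounds shown, and "the series" means these compounds.

Compound 1 `CC1=C(/C=C/C(=O)/C=C/c2ccc(F)cc2)C(C)(C)CCC1` gives 7300 nM in a functional assay on LNCaP cells (Homo sapiens) for cytotoxicity, read by MTT assay, with a stated time of 72 h; on this read-out lower numbers stand for stronger inhibition and higher numbers for weaker inhibition. Compound 2 `CC1=C(/C=C/C(=O)/C=C/c2cccc(C)c2)C(C)(C)CCC1` differs from it by 3-methylphenyl in place of 4-fluorophenyl on a double-bonded chain carbon bound to a double-bonded chain carbon, and in this assay compound 2 gives 17800 nM, a step of a 2.4-fold higher number from compound 1 to compound 2 (0.39 log units; beyond the scatter). Compound 3 `CC1=C(/C=C/C(=O)/C=C/c2ccc(F)cc2)C(C)(C)CCC1O` carries the change hydroxy in place of hydrogen on a saturated ring carbon on the core of compound 1, and in this assay compound 3 gives 3900 nM, a step of a 1.9-fold lower number from compound 1 to compound 3 (0.27 log units; within the scatter). Compound 4 `CC1=C(/C=C/C(=O)/C=C/c2cccc(C)c2)C(C)(C)CCC1O` is related to compound 3 by 3-methylphenyl in place of 4-fluorophenyl on a double-bonded chain carbon bound to a double-bonded chain carbon, the same change as before, now made on a core that differs by hydroxy in place of hydrogen on a saturated ring carbon. Because a 2.4-fold higher number from compound 1 to compound 2 (0.39 log units; beyond the scatter) was modest, the step from compound 3 to compound 4 in this assay is expected to be a 2.4-fold higher number from compound 3 to compound 4 (0.38 log units; beyond the scatter). Within the data shown here, compound 4 is therefore estimated at 9400 nM, most likely between 4000 nM and 22000 nM, a wide range as the expectation rests on the single measured step of a 2.4-fold higher number from compound 1 to compound 2 (0.39 log units; beyond the scatter).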

Compound 4, half-maximal inhibitory concentration: 4100 nM
The estimate for compound 4 lay 2.3-fold (0.36 log units) above the measured number; low and high end bracket the measured number.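

In this assay, the exchange of 4-fluorophenyl for 3-methylphenyl now gives a 1.1-fold higher number from compound 3 to compound 4 (0.02 log units; within the scatter), and the added hydroxy gives a 4.3-fold lower number from compound 2 to compound 4 (0.64 log units; beyond the scatter). For the aryl exchange, the steps on the two cores cannot be told apart: the same change on two cores in this assay, a 2.4-fold higher number (0.39 log units; beyond the scatter) from compound 1 to compound 2 and a 1.1-fold higher number (0.02 log units; within the scatter) from compound 3 to compound 4, 2.3-fold (0.37 log units) apart, within the scatter of two such steps. The same holds for the hydroxy, though one pair of cores in one assay does not establish that either change carries over unaltered to other cores: the same change on two cores in this assay, a 1.9-fold lower number (0.27 log units; within the scatter) from compound 1 to compound 3 and a 4.3-fold lower number (0.64 log units; beyond the scatter) from compound 2 to compound 4, 2.3-fold (0.37 log units) apart, within the scatter of two such steps.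

The compounds shown leave open how other groups in place of 3-methylphenyl, such as a methoxyphenyl or a pyridine, would behave on these two cores. They also leave open whether an amine or a carboxylic acid in place of the hydroxy on the saturated ring carbon would follow the same course.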